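The source may hold more compounds than are shown below. What is called first, only, known or untested is meant among the compounds shown, and "the series" means these compounds.

Measured so far:
Compound 1, `Cc1cccc2cc(C(=O)C3C(=O)CCCC3=O)c(C#N)nc12`, gives 7 nM in an assay for inhibition of 4-hydroxyphenylpyruvate dioxygenase (Arabidopsis thaliana), read by spectrophotometry, with a stated time of 10 min; on this read-out higher numbers stand for weaker inhibition and lower numbers for stronger inhibition.
Compound 2, `COc1nc2c(C)cccc2cc1C(=O)C1C(=O)CC(C)CC1=O`, gives 7 nM in this assay.

On these numbers compound 2 stands level with compound 1: the two values agree at the digits shown, so whatever difference there is lies within the scatter, and neither can be called the stronger inhibitor. Compound 3, `Cc1cccc2cc(C(=O)C3C(=O)CC(C)CC3=O)c(C#N)nc12`, has not yet been measured in this assay. It differs from compound 2 in one place: cyano in place of methoxy on an aromatic carbon, in words cyano in place of methoxy on an aromatic carbon. Compound 1 carries that cyano while compound 2 carries the methoxy, though the two also differ in a second place, and they sit level in this assay. For the measured compounds named here, no pair of measured compounds separated by a single change exists, so that comparison is the only guide. The expected step from compound 2 to compound 3 is no change at the digits printed from compound 2 to compound 3 (within the scatter), which is to say none beyond the scatter. For compound 3 the estimate in this assay is 7 nM, with a range from 3 nM to 15 nM.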

Compound 3, inhibition constant: 7 nM
Compound 3: the middle estimate sits on the measured number at the digits printed; low and high end bracket the measured number.
By their numbers in this assay, from the lowest: compounds 1, 2 and 3 (each within the scatter of the next).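

Cyano in place of methoxy on an aromatic carbon, next to the ring nitrogen, can now be read on its own in this assay: the result is no change at the digits printed from compound 2 to compound 3 (within the scatter). The earlier hint came from a pair that differed in two places, whereas this pair differs in that one place alone, so the two groups are interchangeable here as far as this read-out can tell. The new compound also isolates a second change, methyl in place of hydrogen on a saturated ring carbon, with no change at the digits printed from compound 1 to compound 3 (within the scatter).

As far as these compounds go, it remains open whether a quite different group at this aromatic carbon, such as an amine, a carboxylic acid or a longer chain, would move the number beyond the scatter. No measurement available here explains why these two changes leave the number where it stands.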